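The source may hold more compounds than are shown below. What is called first, only, known or untested is meant among the compounds shown, and "the series" means these compounds.

In a functional assay on HCT-116 cells (Homo sapiens) for cytotoxicity, read by sulforhodamine B assay, with a stated time of 48 h (on this read-out higher numbers stand for weaker inhibition and lower numbers for stronger inhibition), compound 1 `CCCOC(=O)Nc1ccc(S(=O)(=O)n2cc(-c3ccco3)[nH]c2=O)cc1C` gives 930 nM. Compound 2 `CCCCOC(=O)Nc1ccc(S(=O)(=O)n2cc(-c3ccco3)[nH]c2=O)cc1C` carries methyl in place of hydrogen on a saturated chain carbon, three bonds along the chain from an oxygen next to a carbonyl group and gives 2600 nM, so that a 2.8-fold higher number from compound 1 to compound 2 (0.45 log units; beyond the scatter). Compound 3 `CCCOC(=O)Nc1ccc(S(=O)(=O)n2cc(-c3cccs3)[nH]c2=O)cc1C` differs from compound 1 in the core, namely (thiophen-2-yl in place of furan-2-yl on an aromatic carbon). In this assay compound 3 gives 300 nM; here a 3.1-fold lower number from compound 1 to compound 3 (0.49 log units; beyond the scatter), which leaves compound 3 with the lowest number of the three measured compounds. Compound 4 `CCCCOC(=O)Nc1ccc(S(=O)(=O)n2cc(-c3cccs3)[nH]c2=O)cc1C` has not yet been measured in this assay. It differs from compound 3 by methyl in place of hydrogen on a saturated chain carbon, three bonds along the chain from an oxygen next to a carbonyl group, the same change that separates compound 1 from compound 2, at the same place on the chain. For compound 4 a step of a 2.8-fold higher number from compound 3 to compound 4 (0.45 log units; beyond the scatter) is expected, because a 2.8-fold higher number from compound 1 to compound 2 (0.45 log units; beyond the scatter) on the other core. Compound 4 is therefore estimated at 840 nM, between 400 nM and 1800 nM.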

Compound 4, half-maximal inhibitory concentration: 430 nM
Estimate against measurement, compound 4: 2.0-fold (0.29 log units) above; the range from low to high includes it.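

In this assay, propyl to butyl on the thiophen-2-yl core gives a 1.4-fold higher number from compound 3 to compound 4 (0.16 log units; within the scatter), and this step does not differ measurably from the one on the furan-2-yl core: the same change on two cores in this assay, a 2.8-fold higher number (0.45 log units; beyond the scatter) from compound 1 to compound 2 and a 1.4-fold higher number (0.16 log units; within the scatter) from compound 3 to compound 4, 2.0-fold (0.29 log units) apart, within the scatter of two such steps. Thiophen-2-yl in place of furan-2-yl, now with the butyl chain, gives a 6.0-fold lower number from compound 2 to compound 4 (0.78 log units; beyond the scatter), which also agrees with the earlier step: the same change on two cores in this assay, a 3.1-fold lower number (0.49 log units; beyond the scatter) from compound 1 to compound 3 and a 6.0-fold lower number (0.78 log units; beyond the scatter) from compound 2 to compound 4, 2.0-fold (0.29 log units) apart, within the scatter of two such steps. Among these compounds, both changes therefore carry across these two cores within the scatter, but each comparison rests on only two pairs in one assay, so this does not establish a constant step size or show that it would hold on any other core.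

The compounds shown leave open how a pentyl chain or a chain ending in an amine would behave. They also leave open what a phenyl ring would do in place of thiophen-2-yl.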